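Cyclobutyl in place of isopropyl on compound 3

The compounds below may be only part of what the source reports. "The series", "measured", "known", "first", "only" and "open" are said of these compounds alone.

In an ADME assay on the whole organism (Mus musculus, strain CD-1) for pharmacokinetics, at a dose of 10 mg/kg by the oral route (a higher number here means that a larger share of the oral dose reaches the circulation, a lower number that a smaller share of the oral dose reaches the circulation), compound 1 `CCOc1cc([C@](O)(CCN(C)C)[C@H](c2cccc(C)c2)c2cc3cc(Br)ccc3nc2OC)cc(OC)n1` gives 65% and compound 2 `COc1cc([C@](O)(CCN(C)C)[C@@H](c2cc3cc(Br)ccc3nc2OC)c2cccc(OC)c2F)cc(OC(C)C)n1` gives 43%. Compound 3 `COc1cc([C@](O)(CCN(C)C)[C@@H](c2cc3cc(Br)ccc3nc2OC)c2ccnc(OC)c2OC)cc(OC(C)C)n1` stands lowest of the three at 22%. Among the measured compounds shown here, the only measured single change, a number 21 percentage points lower from compound 2 to compound 3 (beyond the scatter), lies beyond the scatter, but it replaces a different group. Compound 4 `COc1cc([C@](O)(CCN(C)C)[C@@H](c2cc3cc(Br)ccc3nc2OC)c2ccnc(OC)c2OC)cc(OC2CCC2)n1` carries cyclobutyl in place of isopropyl on an oxygen on an aromatic ring, with cyclobutyl in place of isopropyl on an oxygen on an aromatic ring. For the measured compounds named here, no measured step touches this group, so no step beyond the scatter is expected, and the expectation starts from compound 3 at 22%. The expected change is a number 2 percentage points higher from compound 3 to compound 4 (within the scatter). For compound 4 the estimated value is 24%, with an expected range from 10% to 40%.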

Compound 4, oral bioavailability: 56%
Estimate against measurement, compound 4: 32 percentage points below, and the stated range ends below it.
By their numbers in this assay, from the lowest: compound 3; then compound 2; then compounds 4 and 1 (each within the scatter of the next).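

Cyclobutyl in place of isopropyl on an oxygen on an aromatic ring gives, in this assay, a number 34 percentage points higher from compound 3 to compound 4 (beyond the scatter). The earlier compounds shown here showed a single step only at another place; this one shows that the group on this oxygen can by itself move the number, with the 2,3-dimethoxypyridin-4-yl group unchanged. No measurement at hand gives a reason for this step.

On these data alone, whether the same swap would give a similar step with the 2-fluoro-3-methoxyphenyl group in place stays open. So does how cyclopentyl or a longer chain on this oxygen would read in this assay.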